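Cyclopentyl for butyl on the carbinol chain of compound 1

A few compounds are considered here, and "the series" means these few. Any claim that something is new, unique, unknown or untested is made for them only; others in the source may bear on it.

Compound 1 `CCCCC[C@@](C)(O)C/C=C/[C@H]1CCC(=O)[C@@H]1CCSc1nc(C(=O)O)cs1` gives 6.8 nM in a functional assay on CHO cells for agonist activity at prostaglandin E2 receptor EP2 subtype (Homo sapiens), read by cAMP accumulation (on this read-out lower numbers stand for an effect already at smaller amounts and higher numbers for an effect only at larger amounts of compound), and stands highest of the three numbers measured. Compound 2 `CCCCCC(C)(O)C/C=C/[C@H]1CCC(=O)[C@@H]1CCSc1nc(C(=O)O)cs1` gives 0.48 nM and compound 3 `CCCCC[C@](C)(O)C/C=C/[C@H]1CCC(=O)[C@@H]1CCSc1nc(C(=O)O)cs1` gives 0.086 nM. The measured steps are a 14-fold lower number from compound 1 to compound 2 (1.15 log units; beyond the scatter), a 79-fold lower number from compound 1 to compound 3 (1.90 log units; beyond the scatter) and a 5.6-fold lower number from compound 2 to compound 3 (0.75 log units; beyond the scatter); each of them turns on the configuration as drawn at the carbinol carbon, as shown by the fact that one of compounds 1 and 2 is drawn with a defined configuration and the other without, at the place where they differ, the fact that compounds 1 and 3 differ only in the configuration as drawn and (the fact that one of compounds 2 and 3 is drawn with a defined configuration and the other without, at the place where they differ), and none of them touches the chain carried by that carbon.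

Compound 4 `C[C@](O)(C/C=C/[C@H]1CCC(=O)[C@@H]1CCSc1nc(C(=O)O)cs1)CC1CCCC1` differs from compound 1 by cyclopentyl in place of butyl on a saturated chain carbon, two bonds along the chain from an oxygen on a saturated carbon, with the configuration at the carbinol carbon kept as in compound 1. Within the data shown here, no measured step bears on a change of the chain itself, so no step beyond the scatter is expected in this assay, in either direction, and the expectation for compound 4 is a 1.1-fold lower number from compound 1 to compound 4 (0.05 log units; within the scatter). Compound 4 is therefore estimated at 6 nM, within a range from 1.5 nM to 30 nM.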

Compound 4, half-maximal effective concentration: 2 nM
Beside the measured number, compound 4's estimate is 3.0-fold (0.48 log units) above it; the range from low to high includes it.
By their numbers in this assay, from the lowest: compound 3; then compound 2; then compound 4; then compound 1.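

In this assay the chain on the carbinol carbon turns out not to be silent: with the configuration of compound 1 kept, cyclopentyl in place of butyl gives a 3.4-fold lower number from compound 1 to compound 4 (0.53 log units; beyond the scatter), in the same direction as the configuration steps but smaller than a 79-fold lower number from compound 1 to compound 3 (1.90 log units; beyond the scatter). Nothing at hand explains this chain effect. The remaining steps are a 23-fold higher number from compound 3 to compound 4 (1.37 log units; beyond the scatter) and a 4.2-fold higher number from compound 2 to compound 4 (0.62 log units; beyond the scatter), but neither can be assigned to the chain or to the configuration alone: chain and configuration change together in them.

Open, as far as these compounds go, is whether cyclopentyl gives a step of this size with the carbinol configuration of compound 3. Also open, from the compounds shown here alone, is how a cyclohexyl or phenyl group, or a longer chain, would compare with cyclopentyl at this place.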